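The source may hold more compounds than are shown below. What is called first, only, known or untested is meant among the compounds shown, and "the series" means these compounds.

Series notes. Compound 1 `O=C(N1CCC=C[C@H]1Cc1ccccc1)n1cc(-c2ccc(-c3ccccc3)cc2)nn1`, compound 2 `O=C(N1CCC=C[C@H]1COCc1ccccc1)n1cc(-c2ccc(-c3ccccc3)cc2)nn1` and compound 3 `O=C(N1C[C@H](O)C=C[C@@H]1COCc1ccccc1)n1cc(-c2ccc(-c3ccccc3)cc2)nn1` are the measured members; compound 4 `O=C(N1C[C@H](O)C=C[C@@H]1Cc1ccccc1)n1cc(-c2ccc(-c3ccccc3)cc2)nn1` is not yet measured. In an assay on HEK293 cells for inhibition of Monoacylglycerol lipase ABHD6 (Homo sapiens), read by fluorescence (a higher number here means a weaker inhibitor, a lower number a stronger inhibitor), compound 1 gives 25.1 nM, compound 2 gives 100 nM and compound 3 gives 5.01 nM, which is the lowest number of the three. The difference between the core of compound 3 and the core of compound 2 is not broken down here. Compound 2 and compound 1 differ in one place, by phenyl in place of benzyloxy on a saturated chain carbon bound to a saturated ring carbon, and in this assay that step read a 4.0-fold lower number from compound 2 to compound 1 (0.60 log units; beyond the scatter). Compound 3 and compound 4 differ by phenyl in place of benzyloxy on a saturated chain carbon bound to a saturated ring carbon, the same change at the same place, so compound 4 stands to compound 3 as compound 1 stands to compound 2. The expected step for compound 4 in this assay is about a 3.1-fold lower number from compound 3 to compound 4 (0.50 log units; beyond the scatter), resting on the earlier step from compound 2 to compound 1 of a 4.0-fold lower number from compound 2 to compound 1 (0.60 log units; beyond the scatter) and on compound 3 starting from 5.01 nM. Compound 4 is accordingly estimated at 1.6 nM, with a plausible range from 0.5 nM to 5 nM.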

Compound 4, half-maximal inhibitory concentration: 3.16 nM
Beside the measured number, compound 4's estimate is 2.0-fold (0.30 log units) below it; measured number inside the range.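

Working notes on the change. In this assay, phenyl in place of benzyloxy on a saturated chain carbon bound to a saturated ring carbon gives a 1.6-fold lower number from compound 3 to compound 4 (0.20 log units; within the scatter), so on this core the step alone cannot be told apart from repeat measurement. Set beside the step on the other core, the change carries over without a measurable difference between the two cores: the same change on two cores in this assay, a 4.0-fold lower number (0.60 log units; beyond the scatter) from compound 2 to compound 1 and a 1.6-fold lower number (0.20 log units; within the scatter) from compound 3 to compound 4, 2.5-fold (0.40 log units) apart, within the scatter of two such steps. This does not show that the step has the same size on both cores, nor that it depends on the core, and two pairs give no rule for any further core.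

Still open, as far as these compounds go, is whether the same carry-over holds when cyclohexyl or pyridyl replaces the phenyl, or when a longer chain joins that ring to the core. Also open, from the compounds shown here alone, is how the step behaves on a core bearing an amine or a methoxy group in place of the hydroxyl of compound 3.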